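The compounds below may be only part of what the source reports. "The series", "measured", "known", "first", "only" and "open" are said of these compounds alone.

Series notes. For the measured compounds named here, in a functional assay on A549 cells (Homo sapiens) for cytotoxicity, read by sulforhodamine B assay, with a stated time of 72 h (on this read-out lower numbers stand for stronger inhibition and higher numbers for weaker inhibition), compound 1 `CC(=O)c1nn(-c2ccc(C)cc2)/c(=N/c2nc(-c3c(C)n(C)n(-c4ccccc4)c3=O)cs2)s1` gives 20700 nM and is the only member of the set with a number rather than a limit. Compound 2 `Cc1c(-c2csc(/N=C3\S/C(=C\c4ccccc4)C(=O)N3c3ccccc3)n2)c(=O)n(-c2ccccc2)n1C` reaches only the limit of this assay, > 100000 nM. Compound 3 `Cc1c(-c2csc(/N=C3\S/C(=C\c4ccc(Cl)cc4)C(=O)N3c3ccccc3)n2)c(=O)n(-c2ccccc2)n1C` likewise reaches only the limit of this assay, > 100000 nM. Going by the values given here, the one measured change between neighbours, a step that the two limits leave unreadable from compound 2 to compound 3, is therefore not readable, and compound 3 stands on a limit shared with compound 2, as noted in the limit of > 100000 nM in this assay, at which 2 of the 3 values shown sit.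

Compound 4 `Cc1c(-c2csc(/N=C3\S/C(=C\c4ccc(N(C)C)cc4)C(=O)N3c3ccccc3)n2)c(=O)n(-c2ccccc2)n1C` differs from compound 3 in one place: dimethylamino in place of chloro on an aromatic carbon. Among the compounds with values here, no measured step in this assay covers an exchange of this kind; the sole measured step, a step that the two limits leave unreadable from compound 2 to compound 3, is itself unreadable, so no direction or size can be drawn from it. With compound 3 at the limit, compound 4 is expected to sit at or near the same limit in this assay, with a step of a number no higher from compound 3 to compound 4 (the limit leaves the size open) that is most probably unreadable. Compound 4 is expected to give 100000 nM in this assay, estimated between 40000 nM and 300000 nM.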

Compound 4, half-maximal inhibitory concentration: > 100000 nM
Compound 4: a limit, no number; the forecaster's own chance of this, stated with the estimate: 70%; the middle value sits exactly at the limit.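

Compound 2, compound 3 and compound 4 all stand on a limit in this assay, so no new step can be read among them: the limit of > 100000 nM in this assay, at which 3 of the 4 values shown sit.

The compounds shown leave open whether hydrogen, chloro and dimethylamino on that aromatic carbon differ at all in this assay.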